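Removing the bromo substituent from compound 3

A few compounds are considered here, and "the series" means these few. Any claim that something is new, unique, unknown or untested is made for them only; others in the source may bear on it.

Compound 1 `O=C1C(=O)N(CN2CCN(c3ccnc4cc(Cl)ccc34)CC2)c2ccccc21`: 71700 nM
Compound 2 `NC(=S)N/N=C1/C(=O)N(CN2CCN(c3ccnc4cc(Cl)ccc34)CC2)c2cccc(Br)c21`: 46400 nM
Compound 3 `NC(=S)N/N=C1/C(=O)N(CN2CCN(c3ccnc4cc(C(F)(F)F)ccc34)CC2)c2cccc(Br)c21`: 26400 nM

In an ADME assay on 184B5 cells (Homo sapiens) for cytotoxicity, read by sulforhodamine B assay, with a stated time of 48 h (on this read-out lower numbers stand for stronger inhibition of growth and higher numbers for weaker inhibition of growth), compound 3 gives the lowest of the three numbers. Among the measured compounds shown here, compound 2 is closest to it, and the one single-place step in this set, a 1.8-fold lower number from compound 2 to compound 3 (0.24 log units; within the scatter), is the change of trifluoromethyl in place of chloro on an aromatic carbon. For the measured compounds named here, compound 1 lies furthest from compound 3, its number standing beyond the scatter above that of compound 3, but the two differ in more than one place, so no single step links them.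

Compound 4 `NC(=S)N/N=C1/C(=O)N(CN2CCN(c3ccnc4cc(C(F)(F)F)ccc34)CC2)c2ccccc21` differs from compound 3 in one place: hydrogen in place of bromo on an aromatic carbon. Going by the values given here, no measured step removes a bromo from this ring; the only measured step concerns trifluoromethyl against chloro and does not bear on this change. With nothing in the data pointing in either direction, no step beyond the scatter is expected in this assay; the expected step is a 1.2-fold higher number from compound 3 to compound 4 (0.08 log units; within the scatter). Compound 4 is therefore estimated at 32000 nM, with a range from 12000 nM to 85000 nM.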

Compound 4, concentration for 50% growth inhibition: 20200 nM
Compound 4: middle estimate off by 1.6-fold (0.20 log units), on the high side, and the stated range covers the measured number.
By their numbers in this assay, from the lowest: compounds 4, 3, 2 and 1 (each within the scatter of the next, the first and the last beyond it).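

In this assay, among the compounds shown here, hydrogen in place of bromo on this aromatic carbon gives a 1.3-fold lower number from compound 3 to compound 4 (0.12 log units; within the scatter), the first measured step at this position, since the earlier step concerned only trifluoromethyl against chloro. Within this pair, which carries trifluoromethyl, the bromo can therefore give way to hydrogen with no step beyond the scatter, so bromo is not required here to keep the read-out where it stands. No measurement at hand bears on why this position responds so little to the change.

Going by these compounds, it remains open whether a larger change on this carbon, such as an amine, a methoxy group or a carboxylic acid, would move the number beyond the scatter. On these data alone, it is also open whether losing the bromo would give a similar step in a compound carrying chloro rather than trifluoromethyl.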